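Anilide-to-pyrazole swap on the shared core, compound 3 outlook

This account rests on a few compounds, and the source may have more. Where it says the series, first, only, none or still open, it means among the compounds named here.

Within the data shown here, compound 1 `COc1ncc(-c2ccc3ncnc(Nc4ccc(OCCO)cc4)c3c2)cc1NS(=O)(=O)c1ccc(F)cc1F` gives 1060 nM in a functional assay on HCT-116 cells (Homo sapiens) for antiproliferative activity, read by sulforhodamine B assay, with a stated time of 72 h (on this read-out lower numbers stand for stronger inhibition and higher numbers for weaker inhibition), the only plain number in the set. Compound 2 `CCCCS(=O)(=O)Nc1cc(-c2ccc3ncnc(Nc4ccc(OCCO)nc4)c3c2)cnc1OC` returns only a limit of the assay in this assay, > 20000 nM. Compound 1 therefore stands alone on the numbers shown, the other value being a limit (the limit of > 20000 nM in this assay, at which 1 of the 2 values shown sits). Compound 3 `COc1ncc(-c2ccc3ncnc(Nc4cnn(CCCO)c4)c3c2)cc1NS(=O)(=O)c1ccc(F)cc1F` differs from compound 1 in one place: 1-(3-hydroxypropyl)-1H-pyrazol-4-yl in place of 4-(2-hydroxyethoxy)phenyl on a nitrogen on an aromatic ring. Among the measured compounds shown here, no step between measured compounds is available, so the size of this change is untested here. Compound 3 is expected to be weaker than compound 1 in this assay by a step of a 2.8-fold higher number from compound 1 to compound 3 (0.45 log units; beyond the scatter), beyond the usual scatter. The estimate for compound 3 is 3000 nM, between 800 nM and 12000 nM.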

Compound 3, half-maximal inhibitory concentration: 480 nM
Compound 3: middle estimate off by 6.3-fold (0.80 log units), on the high side, and the stated range ends above it.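

In this assay the group on a nitrogen on an aromatic ring can be exchanged without loss: 1-(3-hydroxypropyl)-1H-pyrazol-4-yl in place of 4-(2-hydroxyethoxy)phenyl gives a 2.2-fold lower number from compound 1 to compound 3 (0.34 log units; beyond the scatter) on the shared core. A five-membered aromatic ring with 2 hetero atoms therefore serves here at least as well as the six-membered ring of carbon only. Nothing shown gives a cause for this modest step. Still open, as far as these compounds go, is whether the ring or the chain carries the gain, and whether an amine or a carboxylic acid in place of the hydroxy group would keep it.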